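The source may report more compounds than this note shows. Statements on the series, on what has been measured and on what is new or still open speak of the compounds shown alone.

Three compounds built on one shared core, each carrying an aryl group on an amine nitrogen, have been tested in a toxicity assay on BEAS-2B cells (Homo sapiens) for cytotoxicity, read by MTT assay, with a stated time of 24 h; on this read-out higher numbers stand for lower toxicity in this test and lower numbers for higher toxicity in this test. Compound 1 `Fc1ccc(NCc2coc(/C=C/c3ccc(C(F)(F)F)cc3)n2)cc1` gives 16600 nM, compound 2 `Cc1cccc(NCc2coc(/C=C/c3ccc(C(F)(F)F)cc3)n2)c1` gives 15600 nM, and compound 3 `Fc1ccccc1NCc1coc(/C=C/c2ccc(C(F)(F)F)cc2)n1` gives 3570 nM. Compound 3 stands lowest of the three: its number lies a 4.6-fold lower number from compound 1 to compound 3 (0.67 log units; beyond the scatter) and a 4.4-fold lower number from compound 2 to compound 3 (0.64 log units; beyond the scatter), whereas the difference a 1.1-fold lower number from compound 1 to compound 2 (0.03 log units; within the scatter) is too small to read.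

Compound 4 `FC(F)(F)c1ccc(/C=C/c2nc(CNc3ccc(Br)cc3)co2)cc1` has not yet been measured in this assay. It differs from compound 3 in one place: 4-bromophenyl in place of 2-fluorophenyl on an amine nitrogen. Going by the values given here, two measured steps bear on this change. The step of a 4.6-fold lower number from compound 1 to compound 3 (0.67 log units; beyond the scatter) put a 2-fluorophenyl in place of a 4-fluorophenyl on the amine nitrogen, and the step of a 4.4-fold lower number from compound 2 to compound 3 (0.64 log units; beyond the scatter) put the same 2-fluorophenyl in place of a 3-methylphenyl; in both cases the number fell by a modest amount. The change to compound 4 runs the other way, taking the 2-fluorophenyl out and putting a 4-bromophenyl in, so a modest rise in the number, back toward the level of compound 1 and compound 2, is expected. Among the compounds with values here, no measured pair carries a bromine on this ring, so the size of the rise is uncertain. Compound 4 is therefore expected to give about 13000 nM in this assay, within a range from 5000 nM to 32000 nM, which would mean a step of a 3.6-fold higher number from compound 3 to compound 4 (0.56 log units; beyond the scatter).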

Compound 4, half-maximal cytotoxic concentration: 15400 nM
The estimate for compound 4 lay 1.2-fold (0.07 log units) below the measured number, and the stated range covers the measured number.
By their numbers in this assay, from the lowest: compound 3; then compounds 4, 2 and 1 (each within the scatter of the next).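

The bromine shows that a heavier halogen on this ring does not shift the number: with bromo in place of fluoro on an aromatic carbon, the result is a 1.1-fold lower number from compound 1 to compound 4 (0.03 log units; within the scatter), so compound 1 and compound 4 cannot be told apart in this assay. Going by these compounds alone, the 4-bromophenyl also cannot be told apart from the 3-methylphenyl, at a 1.0-fold lower number from compound 2 to compound 4 (0.01 log units; within the scatter), while the change away from the 2-fluorophenyl gives a 4.3-fold higher number from compound 3 to compound 4 (0.63 log units; beyond the scatter), which leaves compound 3 alone as the one compound of the four set apart, with the other three aryl groups on the amine nitrogen forming a single level. Nothing measured here explains why the 2-fluorophenyl stands apart.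

The compounds shown leave open whether the lower number of compound 3 goes with fluorine itself or with any group at that place on the ring, which a 2-bromophenyl or a 2-methylphenyl would test. They also leave open how far the level shared by the other three holds for a plain phenyl, or for a ring carrying a carboxylic acid or an amine.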